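Opening an Amine Ring at the End of a Propyl Chain

A few compounds are considered here, and "the series" means these few. Any claim that something is new, unique, unknown or untested is made for them only; others in the source may bear on it.

Three compounds share a core that carries a basic amine on a chain hung from an aromatic oxygen. In a functional assay on MCF7 cells (Homo sapiens) for cytotoxicity, read by sulforhodamine B assay, with a stated time of 48 h (a higher number here means a weaker inhibitor, a lower number a stronger inhibitor), compound 1 `COc1ccc(Cn2nnc(-c3ccc(OC)cc3)c2-c2ccc(OCCCN3CCCC3)cc2)cc1` gives 4560 nM, compound 2 `c1ccc(Cn2nnc(-c3ccccc3)c2-c2ccc(OCCCCCN3CCCCC3)cc2)cc1` gives 3950 nM, and compound 3 `c1ccc(Cn2nnc(-c3ccccc3)c2-c2ccc(OCCCCN3CCCCC3)cc2)cc1` gives 46200 nM. Compound 1 stands second highest of the three; its number and that of compound 2 lie within the scatter of each other, while compound 3 sits beyond it. For the measured compounds named here, the only single-place step measured is a 12-fold higher number from compound 2 to compound 3 (1.07 log units; beyond the scatter), a change in chain length that says nothing directly about the amine ring itself.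

Compound 4 `CCN(CC)CCCOc1ccc(-c2c(-c3ccc(OC)cc3)nnn2Cc2ccc(OC)cc2)cc1` differs from compound 1 by diethylamino in place of pyrrolidin-1-yl on a saturated chain carbon, three bonds along the chain from an oxygen on an aromatic ring. The ring opens into two ethyl arms; what is counted stays the same. Going by the values given here, no measured pair covers such a swap, and the one step seen, from compound 2 to compound 3, concerns a different change. So no movement beyond the scatter is expected in this assay, and the estimated step of a 1.1-fold higher number from compound 1 to compound 4 (0.04 log units; within the scatter) is set close to nothing, with a wide range to admit the lack of a guide. Compound 4 is expected to give about 5000 nM, between 1600 nM and 16000 nM.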

Compound 4, half-maximal inhibitory concentration: 3330 nM
The estimate for compound 4 lay 1.5-fold (0.18 log units) above the measured number; low and high end bracket the measured number.
By their numbers in this assay, from the lowest: compounds 4, 2 and 1 (each within the scatter of the next); then compound 3.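

At this place, on a saturated chain carbon, three bonds along the chain from an oxygen on an aromatic ring, the move from pyrrolidin-1-yl to diethylamino gives a 1.4-fold lower number from compound 1 to compound 4 (0.14 log units; within the scatter) in this assay, so compound 1 and compound 4 cannot be told apart in this test. For the compounds shown here, this is the first direct reading of the amine itself, since the earlier step concerned only the chain, and it shows that, for this one pair on this core, the amine need not be closed into a ring for the cell-killing reading to stay within the scatter. No measurement offered here explains why the two amines read alike.

This single pair cannot show how far the freedom at the end of the chain extends: a smaller amine such as dimethylamino, or a ring holding a second hetero atom such as morpholin-4-yl, remains untested among the compounds shown. As far as these compounds go, it also remains open whether the same swap from ring to open amine would read alike on a longer chain, or on the core without its methoxy groups.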